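The compounds below may be only part of what the source reports. "The series", "measured", "known", "first", "only" and "open" are said of these compounds alone.

Measured so far:
Compound 1 `C[C@@H]1CCC[C@H](C)N1Cc1cc2c(N)nc(-c3ccc(C4CC4)o3)nc2s1` gives 330 nM in an assay on CHO-K1 cells for antagonist activity at adenosine receptor A1 (Homo sapiens), read by a beta-galactosidase reporter, with stated times of 15 min and 6 h; on this read-out lower numbers stand for stronger inhibition and higher numbers for weaker inhibition.
Compound 2 `C[C@@H]1CCC[C@H](C)N1Cc1cc2c(N)nc(-c3ccc(C(F)F)o3)nc2s1` gives 730 nM in this assay.

For the measured compounds named here, compound 2 has the higher of these two numbers; the only measured step, a 2.2-fold higher number from compound 1 to compound 2 (0.34 log units; beyond the scatter), separates it from compound 1. Compound 3 `Cc1csc(-c2nc(N)c3cc(CN4[C@H](C)CCC[C@@H]4C)sc3n2)n1` carries a different change: 4-methyl-1,3-thiazol-2-yl in place of 5-(difluoromethyl)furan-2-yl on an aromatic carbon. Going by the values given here, no measured step exchanges one ring for another, so the measured step only shows that a small change here moves the number modestly. The step from compound 2 to compound 3 is therefore expected to be about a 1.0-fold lower number from compound 2 to compound 3 (0.02 log units; within the scatter), within the scatter. Compound 3 is estimated at 700 nM, between 200 nM and 2500 nM.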

Compound 3, inhibition constant: 300 nM
Compound 3: the middle estimate sits 2.3-fold (0.37 log units) above what was measured; measured number inside the range.
By their numbers in this assay, from the lowest: compounds 3 and 1 (each within the scatter of the next); then compound 2.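

Replacing the whole ring at this position, rather than only the group carried on the furan, still gives a measurable number in this assay. The 4-methyl-1,3-thiazol-2-yl group gives a 2.4-fold lower number from compound 2 to compound 3 (0.39 log units; beyond the scatter), beyond the scatter, and a 1.1-fold lower number from compound 1 to compound 3 (0.04 log units; within the scatter), within the scatter, so a furan is not needed here to stay level with the 5-cyclopropylfuran-2-yl group.

As far as these compounds go, whether a six-membered ring such as phenyl or pyridin-2-yl, or a thiazole without its methyl group, would hold this number remains open. Nothing measured here explains these steps.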